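Longer Dialkyl Chains on the Carbamate of Compound 3

The source may report more compounds than this note shows. Statements on the series, on what has been measured and on what is new or still open speak of the compounds shown alone.

The measured compounds:
Compound 1 `CCC(CC)C(=O)OCC1CN(C(=O)c2cc(OC)c(OC)c(OC)c2)CCN1C(=O)c1cc(OC)c(OC)c(OC)c1`, which in a functional assay (Oryctolagus cuniculus) for inhibition of platelet-activating factor receptor (Cavia porcellus) (a lower number here means a stronger inhibitor, a higher number a weaker inhibitor), gives 70 nM; 40 nM; 60 nM (3 entries), several repeated entries (the several entries of compound 1 in this assay, 70 nM; 40 nM; 60 nM (3 entries)).
Compound 2 `CCC(C)CNC(=O)OCC1CN(C(=O)c2cc(OC)c(OC)c(OC)c2)CCN1C(=O)c1cc(OC)c(OC)c(OC)c1`, which in this assay gives 470 nM.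
Compound 3 `CCCCN(CCCC)C(=O)OCC1CN(C(=O)c2cc(OC)c(OC)c(OC)c2)CCN1C(=O)c1cc(OC)c(OC)c(OC)c1`, which in this assay gives 1250 nM.

All three share the same core and differ only in the group attached through the carbonyl carbon of the side chain. Among the two compounds with a single number, compound 3 has the highest number, the nearest being compound 2 at a 2.7-fold higher number from compound 2 to compound 3 (0.42 log units; beyond the scatter); compound 1, with several entries, sits well lower than both.

Compound 4 `CCCCCN(CCCCC)C(=O)OCC1CN(C(=O)c2cc(OC)c(OC)c(OC)c2)CCN1C(=O)c1cc(OC)c(OC)c(OC)c1` is the next member: dipentylamino in place of dibutylamino on a carbonyl carbon. Going by the values given here, only one measured step touches this part of the molecule, the change from a (2-methylbutyl)amino to a dibutylamino group, which raised the number by a 2.7-fold higher number from compound 2 to compound 3 (0.42 log units; beyond the scatter). That step swapped a single branched chain for two straight ones; the present step merely lengthens both chains by one carbon each, a smaller change in kind. A small shift is therefore expected, if any, most likely towards a higher number, though a step within the scatter would not be surprising.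

Compound 4 is expected to give about 1600 nM in this assay, within a range of 500 nM to 5000 nM, which would mean an expected step of a 1.3-fold higher number from compound 3 to compound 4 (0.11 log units; within the scatter).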

Compound 4, half-maximal inhibitory concentration: 11400 nM
Compound 4: the middle estimate sits 7.1-fold (0.85 log units) below what was measured; the measured number lies above the stated range.
By their numbers in this assay, from the lowest: compound 2; then compound 3; then compound 4.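

In this assay, this place on the carbonyl carbon proves sensitive to a small enlargement: dipentylamino in place of dibutylamino gives a 9.1-fold higher number from compound 3 to compound 4 (0.96 log units; beyond the scatter), a larger step than the earlier 2.7-fold higher number from compound 2 to compound 3 (0.42 log units; beyond the scatter), although the change is only one added carbon on each chain. Measured against the (2-methylbutyl)amino group, dipentylamino gives a 24-fold higher number from compound 2 to compound 4 (1.38 log units; beyond the scatter), so across these three compounds the number rises as the amino group grows, and it does so unevenly, with most of the rise in the last step. Nothing among the data shown explains why the number climbs so sharply at this step.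

On these data alone, whether a dihexylamino group would raise the number further, or a dipropylamino group would lower it, remains open. So does the effect of tying the two chains into a ring, as in a piperidine.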